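A few compounds are considered here, and "the series" means these few. Any claim that something is new, unique, unknown or untested is made for them only; others in the source may bear on it.

In a functional assay on HaCaT cells (Homo sapiens) for antiproliferative activity, read by sulforhodamine B assay, with a stated time of 3 days (on this read-out lower numbers stand for stronger inhibition and higher numbers for weaker inhibition), compound 1 `COC(=O)c1cc(CCc2cccc(OC)c2)ccc1O` gives 37000 nM, compound 2 `COC(=O)c1cc(CCc2cc(OC)ccc2O)ccc1O` gives 1100 nM, and compound 3 `COC(=O)c1cc(CCc2cc(OC)ccc2C(C)=O)ccc1O` gives 41 nM, the lowest of the three numbers. Compound 4 `COC(=O)c1cc(CCc2cc(OC)c(C(C)(C)C)cc2C(C)=O)ccc1O` differs from compound 3 by tert-butyl in place of hydrogen on an aromatic carbon, ortho to a methoxy group and meta to an acetyl group: tert-butyl in place of hydrogen on an aromatic carbon. The nearest evidence is large: hydroxy in place of hydrogen gave a 34-fold lower number from compound 1 to compound 2 (1.53 log units; beyond the scatter), acetyl in place of hydrogen gave a 900-fold lower number from compound 1 to compound 3 (2.96 log units; beyond the scatter), and acetyl in place of hydroxy gave a 27-fold lower number from compound 2 to compound 3 (1.43 log units; beyond the scatter). None of these steps introduces tert-butyl, so they give no direction, and no step beyond the scatter is expected in this assay. The expected step is a 1.2-fold higher number from compound 3 to compound 4 (0.09 log units; within the scatter). Compound 4 is estimated at 50 nM, with an expected range of 10 nM to 300 nM.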

Compound 4, half-maximal inhibitory concentration: 8200 nM
Compound 4: middle estimate off by 160-fold (2.21 log units), on the low side, and the stated range ends below it.
By their numbers in this assay, from the lowest: compound 3; then compound 2; then compound 4; then compound 1.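

Putting tert-butyl on this aromatic carbon, ortho to a methoxy group and meta to an acetyl group, gives a 200-fold higher number from compound 3 to compound 4 (2.30 log units; beyond the scatter) in this assay. This is the first change shown at this carbon, and the first shown to raise the number, whereas the earlier steps all lowered it. Nothing measured here explains the rise. The compounds shown leave open whether a methyl group, a chlorine atom or an amine on this same carbon would also raise the number, and whether tert-butyl would do so elsewhere on this ring.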